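Benzylsulfanyl series: chloro on the benzyl ring

The source may hold more compounds than are shown below. What is called first, only, known or untested is meant among the compounds shown, and "the series" means these compounds.

Compound 1 `COc1ccc(C2N=C(SCc3ccccc3)NC(C)=C2C(=O)Nc2ccc(F)cc2)cc1OC` and compound 2 `COc1ccc(C2N=C(SCc3cccc(Cl)c3)NC(C)=C2C(=O)Nc2ccc(F)cc2)cc1OC` share one core; compound 3 `CC1=C(C(=O)Nc2ccc(Br)cc2)C(c2ccc(Cl)cc2Cl)N=C(SCc2ccccc2)N1` is built on another, and the difference between the two cores is not broken down here. In a functional assay on the whole organism (artery, strain albino) with Rattus norvegicus as the target, with a stated time of 30 min, at a dose of 10 mg/kg by the oral route (a higher number here means more inhibition at the dose given (going by the name of the read-out), a lower number less inhibition), compound 1 gives 3.6%, compound 2 gives 5.2% and compound 3 gives 3.6%. Compound 3 and compound 1 stand level at the digits shown. The change chloro in place of hydrogen on an aromatic carbon made the step of a number 1.6 percentage points higher from compound 1 to compound 2 (within the scatter). Compound 4 `CC1=C(C(=O)Nc2ccc(Br)cc2)C(c2ccc(Cl)cc2Cl)N=C(SCc2ccccc2Cl)N1` is not yet measured; it differs from compound 3 by chloro in place of hydrogen on an aromatic carbon, the same kind of change as before, though here the chloro enters ortho to a large group rather than meta to a large group. Going by the values given here, only one measured instance of this kind of change exists, and the surroundings are not the same, so the expectation rests on a thin base. Compound 4 is expected to stay close to compound 3, with an estimated step of a number 1.4 percentage points higher from compound 3 to compound 4 (within the scatter), because the earlier step of a number 1.6 percentage points higher from compound 1 to compound 2 (within the scatter) stayed within the scatter. The estimate for compound 4 in this assay is 5%, with a range from -5% to 15%.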

Compound 4, a percentage reported as inhibition, in the whole organism at one dose (the size of the read-out at that dose, not a potency): 5.7%
For compound 4 the middle estimate is 0.7 percentage points below the measured one; the range from low to high includes it.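

On the second core, chloro in place of hydrogen on an aromatic carbon gives a number 2.1 percentage points higher from compound 3 to compound 4 (within the scatter) in this assay. Set beside the step on the first core, the change shows no detectable dependence on the core in this assay: the same change on two cores in this assay, a number 1.6 percentage points higher (within the scatter) from compound 1 to compound 2 and a number 2.1 percentage points higher (within the scatter) from compound 3 to compound 4, 0.5 percentage points apart, within the scatter of two such steps

This does not show that the change affects inhibition on either core, as both steps lie within the scatter, and agreement between two steps of this size says little about how well a real effect would carry over; moreover, in compound 4 the chloro stands ortho to a large group, a place not shared by compound 2, so core and position are not separated here.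

Open, from the compounds shown here alone, is whether the chloro ortho to a large group behaves the same on the core of compound 1. Also open, going by these compounds, is whether a group other than chloro, such as a methoxy or a nitrile on the benzyl ring, or an amine or a carboxylic acid in place of the benzylsulfanyl group, would give a step beyond the scatter.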